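The compounds below may be only part of what the source reports. "The series", "measured", "known", "first", "only" and "open" are said of these compounds alone.

In an in vitro ADME assay on microsomes from liver (Homo sapiens) for metabolic stability, read by LC-MS (on this read-out higher numbers stand for a longer-lived compound and lower numbers for a shorter-lived compound), compound 1 `O=C(CCC1CCCC1)N1CCCN(C(=O)Nc2ccccc2)CC1` gives 0.05 h. In this assay compound 2 `CC(C)c1ccc(NC(=O)N2CCCN(C(=O)CCC3CCCC3)CC2)cc1` gives 0.117 h, and compound 3 `CC(C)(C)c1ccc(NC(=O)N2CCCN(C(=O)C3CCCCC3)CC2)cc1` gives 0.0667 h. Compound 3 thus stands second highest of the three numbers, and its gaps to compound 1 and to compound 2 both lie within the scatter. Among the measured compounds shown here, the only measured step, a 2.3-fold higher number from compound 1 to compound 2 (0.37 log units; beyond the scatter), concerns a substituent on an aromatic carbon of the urea side and does not involve the carbonyl carbon. Compound 4 `CN(C)c1ccc(C(=O)N2CCCN(C(=O)Nc3ccc(C(C)(C)C)cc3)CC2)cc1` differs from compound 3 by 4-(dimethylamino)phenyl in place of cyclohexyl on a carbonyl carbon. For the measured compounds named here, no measured step bears on this change, so compound 4 is expected to show a 1.2-fold higher number from compound 3 to compound 4 (0.08 log units; within the scatter), a step not beyond the scatter. Compound 4 is therefore estimated at 0.08 h, within 0.03 h to 0.2 h.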

Compound 4, half-life: 0.0667 h
For compound 4 the middle estimate is 1.2-fold (0.08 log units) above the measured one, within the range that was stated.
By their numbers in this assay, from the lowest: compounds 1, 3, 4 and 2 (each within the scatter of the next, the first and the last beyond it).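

In this assay, 4-(dimethylamino)phenyl in place of cyclohexyl on a carbonyl carbon gives no change at the digits printed from compound 3 to compound 4 (within the scatter). Among the compounds shown here, this is the first reading at this position, which the earlier step on the aromatic carbon did not touch, and here an aromatic ring carrying a nitrogen replaces a non-aromatic ring of carbon only with no change beyond the scatter. No measured evidence accounts for this result. Still open, going by these compounds, is whether a carboxylic acid in place of the dimethylamino group, or a piperidine ring or a longer chain on this carbonyl carbon, would give a step beyond the scatter.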